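The source may hold more compounds than are shown below. What is called first, only, known or untested is meant among the compounds shown, and "the series" means these compounds.

Working notes on a small series of three measured compounds and one untested analogue. In a functional assay on HaCaT cells (Homo sapiens) for cytotoxicity, read by ELISA and LDH release, with a stated time of 6 h, tested at 50 ug/mL (on this read-out lower numbers stand for a stronger effect and higher numbers for a weaker effect at the one concentration tested), compound 1 `C=C1C(=O)O[C@H](C2=C(C)C(OC)CC2=O)[C@@H]1[C@@H](O)CC(C)=O` gives 2%, compound 2 `C=C1C(=O)O[C@H](C2=C(C)C(O)CC2=O)[C@@H]1CCC(C)=O` gives 0% and compound 3 `C=C1C(=O)O[C@H](C2=C(C)[C@@H](OC)CC2=O)[C@@H]1CCC(C)=O` gives 0%. Compound 3 is level with compound 2 at the digits shown, the pair making up the lowest two numbers of the three, and it differs from compound 1 only within the scatter; all three sit near the bottom of the scale. Among the measured compounds shown here, compound 4 `C=C1C(=O)O[C@H](C2=C(C)[C@@H](O)CC2=O)[C@@H]1CCC(C)=O` is the untested analogue. hydrogen in place of methyl on an oxygen on a saturated carbon No comparable step has been measured within this set. Because compound 3 shows 0% and compound 2 shows 0%, no step beyond the scatter is expected in this assay in either direction. The expected value for compound 4 is 1%, with a range of 0% to 10%, which means an expected step of a number 1 percentage points higher from compound 3 to compound 4 (within the scatter).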

Compound 4, a percentage reported as activity, at one concentration (the size of the read-out at that concentration, not a potency): 0%
Beside the measured number, compound 4's estimate is 1 percentage points above it, within the range that was stated.
By their numbers in this assay, from the lowest: compounds 2, 3, 4 and 1 (each within the scatter of the next).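

In this assay, the change from methoxy to hydroxy on an oxygen on a saturated carbon now has a measured step: no change at the digits printed from compound 3 to compound 4 (within the scatter). A second step, no change at the digits printed from compound 2 to compound 4 (within the scatter), concerns the drawing of the stereocentre only: the fact that one of compounds 2 and 4 is drawn with a defined configuration and the other without, at the place where they differ. On this read-out, neither change separates the compounds, though all of these values lie near the bottom of the scale.

On these data alone, it remains open whether an amine in place of the hydroxy, or a longer chain in place of the methyl on this oxygen, would read differently. As far as these compounds go, the opposite configuration at this ring carbon also remains open.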